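Substituent swap on the fused ring: toward compound 4

A few compounds are considered here, and "the series" means these few. Any claim that something is new, unique, unknown or untested is made for them only; others in the source may bear on it.

Measured compounds in a functional assay on HEK293 cells for agonist activity at Free fatty acid receptor 1 (Homo sapiens), read by fluorescence and calcium flux, with a stated time of 10 min; a lower number here means that less compound is needed, a higher number that more compound is needed for the effect:
compound 1 `CC#C[C@@H](CC(=O)O)c1ccc(OC[C@H]2COc3ccc(F)cc3O2)cc1` gives 210 nM
compound 2 `CC#C[C@@H](CC(=O)O)c1ccc(OC[C@H]2COc3ccc(OC(C)C)cc3O2)cc1` gives 280 nM
compound 3 `CC#C[C@@H](CC(=O)O)c1ccc(OC[C@H]2COc3ccc(OC(F)(F)F)cc3O2)cc1` gives 700 nM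

Compound 3 stands at the highest of the three numbers in this assay. Its distance from compound 2 is a 2.5-fold higher number from compound 2 to compound 3 (0.40 log units; beyond the scatter), and from compound 1 it is a 3.3-fold higher number from compound 1 to compound 3 (0.52 log units; beyond the scatter), both beyond the scatter; the step of a 1.3-fold higher number from compound 1 to compound 2 (0.12 log units; within the scatter) stays within it.

Compound 4 `CC#C[C@@H](CC(=O)O)c1ccc(OC[C@H]2COc3ccc(C(C)=O)cc3O2)cc1` is not yet measured. The change from compound 3 is acetyl in place of trifluoromethoxy on an aromatic carbon. Among the compounds with values here, no measured step covers an acetyl group at this position, so the only guidance is that the three groups tried so far all gave numbers within a narrow band, with the trifluoromethoxy of compound 3 at the high end. Compound 4 is therefore expected to show a modest step toward a lower number, estimated as a 2.0-fold lower number from compound 3 to compound 4 (0.30 log units; within the scatter). Compound 4 is estimated at 350 nM, with a range from 120 nM to 1000 nM.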

Compound 4, half-maximal effective concentration: > 30000 nM
Compound 4 ended at the assay's limit; the forecaster's own chance of this, stated with the estimate: 3%; middle value at least 85-fold (1.93 log units) from the limit.
By their numbers in this assay, from the lowest: compounds 1 and 2 (each within the scatter of the next); then compound 3. At a limit, above all of these: compound 4.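

For compound 4 the read-out in this assay is a limit of the assay and not a number: the limit of > 30000 nM in this assay, at which 1 of the 4 values shown sits. Fluoro, isopropoxy and trifluoromethoxy on this aromatic carbon differ by modest steps at most, whereas acetyl gives an at least 42-fold higher number from compound 3 to compound 4 (1.63 log units; beyond the scatter), along with an at least 100-fold higher number from compound 2 to compound 4 (2.02 log units; beyond the scatter) and an at least 140-fold higher number from compound 1 to compound 4 (2.15 log units; beyond the scatter). This position therefore responds sharply to the identity of the group, and the counts do not separate the change: acetyl has fewer heavy atoms than trifluoromethoxy and the same count of hydrogen-bond acceptors.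

The compounds shown leave open whether the loss belongs to the carbonyl generally or to acetyl alone, a question that a methyl ester, a primary amide or a nitrile here would address. As far as these compounds go, how an amine or a hydroxyl at this position would behave also remains open.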